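This account rests on a few compounds, and the source may have more. Where it says the series, first, only, none or still open, it means among the compounds named here.

Working notes on the series.

The series measured so far comprises compound 1 `CC(C)Cc1ccc2c(NCCCNCc3ccco3)ccnc2c1`, compound 3 `CCC(CC)c1ccc2c(NCCCNCc3ccco3)ccnc2c1` and compound 2 `COc1ccc(Oc2ccc3c(NCCCNCc4cc(F)ccc4OC)ccnc3c2)cc1`. In a physicochemical assay for acid dissociation, compound 1 gives 9.47, compound 3 gives 9.47 and compound 2 gives 9.28. For the measured compounds named here, the one step recorded between two measured compounds, no change at the digits printed from compound 1 to compound 3 (within the scatter), shows that swapping one alkyl substituent for another on the aromatic carbon of the shared core leaves the read-out untouched. Compound 2 holds the lowest of the three numbers, yet its values against compound 1 and against compound 3 both lie within the scatter, so no ordering can be read among them.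

The next compound, compound 4 `COc1ccc(F)cc1CNCCCNc1ccnc2cc(Oc3cccc(N(C)C)c3)ccc12`, differs from compound 2 in a single place: 3-(dimethylamino)phenyl in place of 4-methoxyphenyl on an oxygen on an aromatic ring. Going by the values given here, no measured step touches the aryl ether substituent on the shared core; the only recorded step, no change at the digits printed from compound 1 to compound 3 (within the scatter), concerns a different position and was flat. The change from compound 2 to compound 4 also sits far from the secondary amine of the chain, and nothing in the data links a substituent on that ether oxygen to a shift in this assay.

Compound 4 is therefore expected to read essentially as compound 2, with a step of a number 0.02 log units higher from compound 2 to compound 4 (within the scatter) that stays within the scatter. The estimate for compound 4 in this assay is 9.3, with a range from 9 to 9.6.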

Compound 4, acid dissociation constant: 9.28
Compound 4: middle estimate off by 0.02 log units, on the high side; measured number inside the range.
By their numbers in this assay, from the lowest: compounds 2, 4, 1 and 3 (each within the scatter of the next).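

In this assay, for the compounds shown here, 3-(dimethylamino)phenyl in place of 4-methoxyphenyl on an oxygen on an aromatic ring gives no change at the digits printed from compound 2 to compound 4 (within the scatter), the first reading for a change at this position. Taken with no change at the digits printed from compound 1 to compound 3 (within the scatter), which concerns a different place on the shared core, this makes two single-place changes in the series, each with no change at the digits printed, though the two steps cover different compounds and claim no pattern beyond them. Nothing available bears on why this exchange of aryl groups leaves the reading as it stands.

The compounds shown leave open whether a carboxylic acid or a primary amine on the phenyl ring, or a longer alkyl chain in place of that ring on the oxygen, would read the same as compound 2. This single step also exchanges the group and its printed ring number together, so 4-(dimethylamino)phenyl, which would pair directly with 4-methoxyphenyl, remains an open comparison.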